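Aryl substituent on the shared core and HDAC6 inhibition

This account rests on a few compounds, and the source may have more. Where it says the series, first, only, none or still open, it means among the compounds named here.

Measured so far:
compound 1 `O=C(NO)c1ccc(NCc2nc(-c3ccccc3)nn2-c2cccc(Cl)c2)cc1` gives 678 nM
compound 2 `Cc1cccc(-n2nc(-c3ccccc3)nc2CNc2ccc(C(=O)NO)cc2)c1` gives 388 nM
compound 3 `Cc1ccc(-n2nc(-c3ccccc3)nc2CNc2ccc(C(=O)NO)cc2)cc1` gives 310 nM

All three numbers come from an assay on Sf9 cells for inhibition of protein deacetylase HDAC6 (Homo sapiens), read by fluorescence, with a stated time of 40 min; on this read-out lower numbers stand for stronger inhibition and higher numbers for weaker inhibition. Compound 3 holds the lowest number of the three; its gap to compound 2 lies within the scatter, while a 2.2-fold lower number from compound 1 to compound 3 (0.34 log units; beyond the scatter) is beyond it. The steps of a 1.7-fold lower number from compound 1 to compound 2 (0.24 log units; within the scatter) and a 1.3-fold lower number from compound 2 to compound 3 (0.10 log units; within the scatter) show that swapping the group on the aryl ring moves the number only modestly.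

Compound 4 `COc1ccc(-n2nc(-c3ccccc3)nc2CNc2ccc(C(=O)NO)cc2)cc1` differs from compound 3 by methoxy in place of methyl on an aromatic carbon. For the measured compounds named here, no measured step covers methoxy in place of methyl; the nearest are the modest aryl-group steps above. The step of a 1.1-fold lower number from compound 3 to compound 4 (0.03 log units; within the scatter) is therefore expected to stay within the scatter. Compound 4 is estimated at 290 nM, with a range of 140 nM to 600 nM.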

Compound 4, half-maximal inhibitory concentration: 127 nM
Compound 4: the middle estimate sits 2.3-fold (0.36 log units) above what was measured; measured number outside the range, below it.
By their numbers in this assay, from the lowest: compound 4; then compounds 3, 2 and 1 (each within the scatter of the next, the first and the last beyond it).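

Methoxy in place of methyl on this aromatic carbon gives a larger step than any among the earlier compounds (a 2.4-fold lower number from compound 3 to compound 4 (0.39 log units; beyond the scatter)). The 4-methoxyphenyl group also stands clearly apart from the other aryl groups (a 3.1-fold lower number from compound 2 to compound 4 (0.49 log units; beyond the scatter); a 5.3-fold lower number from compound 1 to compound 4 (0.73 log units; beyond the scatter)). Nothing available bears on what lies behind this step.

Open, from the compounds shown here alone, is whether ethoxy, hydroxy or a dimethylamino group on the same carbon would give a similar number. Also open, going by these compounds, is how a 3-methoxyphenyl group would compare with the 4-methoxyphenyl group.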